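Benzoxazolyl in Place of Phenyl in an Agonist Series

This account rests on a few compounds, and the source may have more. Where it says the series, first, only, none or still open, it means among the compounds named here.

Compound 1: `O=C(O)CCCSCCN1C(=O)CC[C@@H]1/C=C/[C@@H](O)Cc1cccc(OCc2ccncc2)c1`, 46 nM
Compound 2: `O=C(O)c1csc(SCCN2C(=O)CC[C@@H]2/C=C/[C@@H](O)Cc2cccc(-c3ccccc3)c2)n1`, 8 nM

Of the compounds shown here, two have been tested in a functional assay on CHO cells for agonist activity at prostaglandin E2 receptor EP4 subtype (Rattus norvegicus), read by cAMP accumulation and immunoassay, with a stated time of 10 min; on this read-out lower numbers stand for an effect already at smaller amounts and higher numbers for an effect only at larger amounts of compound. Compound 1 `O=C(O)CCCSCCN1C(=O)CC[C@@H]1/C=C/[C@@H](O)Cc1cccc(OCc2ccncc2)c1` gives 46 nM. Compound 2 `O=C(O)c1csc(SCCN2C(=O)CC[C@@H]2/C=C/[C@@H](O)Cc2cccc(-c3ccccc3)c2)n1` gives 8 nM, the lower of the two numbers; its gap to compound 1 is beyond the usual scatter, so compound 2 is the more potent of the pair. Compound 3 `O=C(O)c1csc(SCCN2C(=O)CC[C@@H]2/C=C/[C@@H](O)Cc2cccc(-c3nc4ccccc4o3)c2)n1` has not yet been measured. It differs from compound 2 in one place: 1,3-benzoxazol-2-yl in place of phenyl on an aromatic carbon. The two measured compounds differ from each other in several places at once, so no single change has been isolated, and nothing tested so far speaks directly to this exchange. The expected step of a 1.3-fold lower number from compound 2 to compound 3 (0.12 log units; within the scatter) is therefore small, staying within the usual scatter rather than moving clearly in either direction. Compound 3 is expected to give 6 nM in this assay, within a range from 1.5 nM to 25 nM.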

Compound 3, half-maximal effective concentration: 2.2 nM
Compound 3: the middle estimate sits 2.7-fold (0.44 log units) above what was measured; measured number inside the range.
By their numbers in this assay, from the lowest: compound 3; then compound 2; then compound 1.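

Within the data shown here, this is the first change that can be read at a single place. On an aromatic carbon of a six-membered aromatic ring of carbon only, meta to a large group, 1,3-benzoxazol-2-yl in place of phenyl gives a 3.6-fold lower number from compound 2 to compound 3 (0.56 log units; beyond the scatter) in this assay and so moves the number beyond the usual scatter. The position therefore tolerates a group of 9 heavy atoms with 2 hydrogen-bond acceptors in place of one of 6 heavy atoms with none, though no measurement here explains why the number falls.

From the compounds shown here alone, it remains open whether both rings of the new group are needed, which oxazol-2-yl or benzothiazol-2-yl at this place could help to show. Going by these compounds, how the same exchange behaves on the core of compound 1 also remains open.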